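Replacing a Ring Chloro With an Arylamino Group

The compounds below may be only part of what the source reports. "The series", "measured", "known", "first", "only" and "open" are said of these compounds alone.

compound 1 `C=CCOc1ccc(C(=O)Nc2cccc(C)n2)cc1`: 6000 nM
compound 2 `C#CCOc1ccc(C(=O)Nc2cccc(C)n2)cc1`: 19400 nM
compound 3 `CCCOc1ccc(C(=O)Nc2cccc(Cl)n2)cc1`: a limit only, > 100000 nM

Compound 3 stands at the weak end of what has been measured: in an in vitro assay on HEK-tsA201 cells for antagonist activity at Neuronal acetylcholine receptor; alpha4/beta2 (Homo sapiens), read by fluorescence and calcium flux (on this read-out higher numbers stand for weaker inhibition and lower numbers for stronger inhibition), compound 3 gives only a limit of the assay, > 100000 nM. It sits at the limit of > 100000 nM in this assay, at which 1 of the 3 values shown sits. Compound 4 `CCCOc1ccc(C(=O)Nc2cccc(Nc3ccc(Cl)cc3)n2)cc1` differs from compound 3 by (4-chlorophenyl)amino in place of chloro on an aromatic carbon. Among the compounds with values here, the single measured step, a 3.2-fold higher number from compound 1 to compound 2 (0.51 log units; beyond the scatter), concerns a different part of the structure, so no measured step bears on this change, and compound 3 itself offers no number to build on. Compound 4 is therefore expected, with wide uncertainty, to give about 30000 nM in this assay, between 4000 nM and 200000 nM. That estimate corresponds to an expected step of an at least 3.3-fold lower number from compound 3 to compound 4 (0.52 log units; beyond the scatter).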

Compound 4, half-maximal inhibitory concentration: > 100000 nM
Compound 4 was reported as a limit; the forecaster's own chance of this, stated with the estimate: 40%; at least 3.3-fold (0.52 log units) between middle value and limit.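

Compound 3 gives only a limit in this assay, > 100000 nM. Within the data shown here, compound 4 also gives only a limit, > 100000 nM, so no step between the two can be read. From the compounds shown here alone, how far (4-chlorophenyl)amino in place of chloro changes inhibition remains open.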